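The compounds below may be only part of what the source reports. "The series", "measured", "known", "first", "only" and "open" are said of these compounds alone.

Measured so far in a functional assay on SK-HEP1 cells (Homo sapiens) for cytotoxicity, read by MTT assay, with a stated time of 48 h; on this read-out higher numbers stand for weaker inhibition and lower numbers for stronger inhibition
- compound 1 `COc1cc2nc(Cl)nc(Nc3cccc(Cl)c3)c2cc1OC` gives 16500 nM
- compound 2 `COc1cc2nc(Cl)nc(Nc3ccc(Cl)c(C(F)(F)F)c3)c2cc1OC` gives 8800 nM
- compound 3 `COc1cc2nc(Cl)nc(Nc3ccc(Oc4ccccc4)cc3)c2cc1OC` gives 15300 nM

Compound 1 stands level with compound 2 and compound 3, as all three values lie within the scatter of each other. Compound 4 `COc1cc2nc(Cl)nc(NCc3ccccc3)c2cc1OC` has benzyl in place of 3-chlorophenyl on a nitrogen on an aromatic ring. Among the measured compounds shown here, no measured pair shows this change directly. The group on that nitrogen varies among the measured compounds, yet compound 2 at 8800 nM and compound 3 at 15300 nM stay within the scatter of compound 1 at 16500 nM and so no step beyond the scatter is expected in this assay here. The expected step is a 1.2-fold higher number from compound 1 to compound 4 (0.08 log units; within the scatter) in this estimate. Compound 4 is expected at 20000 nM with an estimated range from 8000 nM to 50000 nM on this read-out.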

Compound 4, half-maximal inhibitory concentration: 19800 nM
Compound 4: middle estimate off by 1.0-fold (0.00 log units), on the high side; low and high end bracket the measured number.
By their numbers in this assay, from the lowest: compounds 2, 3, 1 and 4 (each within the scatter of the next, the first and the last beyond it).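

In this assay, among the compounds shown here, benzyl in place of 3-chlorophenyl on the nitrogen gives a 1.2-fold higher number from compound 1 to compound 4 (0.08 log units; within the scatter), the first direct single-place comparison at this position. Exchanging this aryl group for benzyl therefore leaves the number level, so this pair gives no sign that the nitrogen substituent matters. No measurement on hand explains this result.

Still open, from the compounds shown here alone, is whether an amine, a carboxylic acid or a longer chain in place of benzyl would give a step beyond the scatter. Going by these compounds, the contribution of the shared core also remains open.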